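Halogen Swap on the Aryl Ring and Cell Tolerability

A few compounds are considered here, and "the series" means these few. Any claim that something is new, unique, unknown or untested is made for them only; others in the source may bear on it.

Three compounds share one core. Compound 1 `C[C@]1(CN2CCc3oc(-c4ccc(F)cc4)nc3C2)Cn2cc([N+](=O)[O-])nc2O1` and compound 2 `C[C@]1(CN2CCc3oc(-c4ccc(F)cc4)cc3C2)Cn2cc([N+](=O)[O-])nc2O1` differ from compound 3 `C[C@]1(CN2CCc3nc(-c4cccc(F)c4)ccc3C2)Cn2cc([N+](=O)[O-])nc2O1` in the fused ring that carries the fluorophenyl group. In an ADME assay on Vero cells (Chlorocebus sabaeus) for cytotoxicity, read by MTT assay, with a stated time of 72 h (a higher number here means that more compound is tolerated, a lower number that less compound is tolerated), compound 1 gives > 32 ug/mL, which is a limit of the assay and not a number. Compound 2 has "not determined" (no result reported) in this assay. Compound 3 also reaches only a limit, > 32 ug/mL in this assay. Its standing is therefore set by the limit of > 32 ug/mL in this assay, at which 2 of the 3 values shown sit, not by a measured value. The untested compound 4 `C[C@]1(CN2CCc3nc(-c4cc(Cl)ccc4F)ccc3C2)Cn2cc([N+](=O)[O-])nc2O1` carries 5-chloro-2-fluorophenyl in place of 3-fluorophenyl on an aromatic carbon. No step between measured compounds is shown, and the change is expected to stay within the usual scatter. The step from compound 3 to compound 4 is estimated at a step that the limit leaves unreadable from compound 3 to compound 4. Compound 4 is expected to give about 40 ug/mL, between 20 ug/mL and 100 ug/mL.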

Compound 4, half-maximal cytotoxic concentration: > 32 ug/mL
Compound 4: a limit, no number; the forecaster's own chance of this, stated with the estimate: 75%; the middle value is on the limit's open side.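

Among the compounds shown here, compound 3 and compound 4 both reach only a limit in this assay, and no step between them can be read. The compounds shown leave open whether 5-chloro-2-fluorophenyl in place of 3-fluorophenyl changes how much compound the cells tolerate.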